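Swapping Carbamoyl for Amino: Expected Shift in Lipophilicity

The source may report more compounds than this note shows. Statements on the series, on what has been measured and on what is new or still open speak of the compounds shown alone.

Measured so far in a physicochemical assay for lipophilicity; a lower number here means a more polar compound, a higher number a more lipophilic compound:
compound 1 `O=C(NC1(C(=O)NO)CCS(=O)(=O)CC1)c1ccc(C#Cc2ccccc2)cc1` gives 3
compound 2 `NC(=O)C[C@H](NC(=O)c1ccc(C#Cc2ccccc2)cc1)C(=O)NO` gives 1
compound 3 `O=C(NC1(C(=O)NO)CCSCC1)c1ccc(C#Cc2ccccc2)cc1` gives > 3

The value for compound 3 is a limit of this assay rather than a number, as told by the limit of > 3 in this assay, at which 1 of the 3 values shown sits. Among the two real numbers, compound 2 stands lowest; its nearest neighbour is compound 1, which sits higher by a gap beyond the usual scatter. All three share the same core, and differ only in the part carrying the hydroxamic acid.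

Compound 4 `NC[C@H](NC(=O)c1ccc(C#Cc2ccccc2)cc1)C(=O)NO` has not yet been measured. It differs from compound 2 in one place: amino in place of carbamoyl on a saturated chain carbon, two bonds along the chain from an amide-type nitrogen and a carbonyl carbon. Within the data shown here, no measured pair shows this same change, so its size must be guessed from the structures alone. The carbamoyl that leaves is larger than the amino that enters, yet an amino on a saturated chain carbon is expected to pull the distribution coefficient down rather than up, so a drop beyond the scatter is expected. For compound 4 the expected value in this assay is 0.3, within -0.6 to 1.2. That estimate means an expected step of a number 0.70 log units lower from compound 2 to compound 4 (beyond the scatter).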

Compound 4, distribution coefficient: 2
Estimate against measurement, compound 4: 1.70 log units below, outside the stated range (above it).
By their numbers in this assay, from the lowest: compound 2; then compound 4; then compound 1.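

On a saturated chain carbon, two bonds along the chain from an amide-type nitrogen and a carbonyl carbon, putting amino in place of carbamoyl moves the reading in this assay upward: a number 1.00 log units higher from compound 2 to compound 4 (beyond the scatter). Among these compounds, the earlier compounds offered no one-place change at this position, so this pair is the first sign that the position responds to what sits there, and that the direction is upward for this swap. No measurement shown here bears on why the number moves this way.

On these data alone, whether a hydroxyl, a carboxylic acid or a longer chain such as aminoethyl at the same place would shift the number in the same direction remains open. A single pair also cannot say whether this step would hold on a different core.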